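Swapping methyl for fluoro on a quinolinone core

The source may hold more compounds than are shown below. What is called first, only, known or untested is meant among the compounds shown, and "the series" means these compounds.

Measured compounds:
- compound 1 `C#CCn1c(=O)c(C=O)cc2cc(F)ccc21`, > 100000 nM
- compound 2 `C#CCn1c(=O)c(C=O)cc2cc(C)ccc21`, > 100000 nM
- compound 3 `C#CCn1c(=O)c(/C=C/C(=O)/C=C(O)/C=C/c2ccc(O)c(OC)c2)cc2cc(C)ccc21`, 12800 nM

In a functional assay on SK-OV-3 cells (Homo sapiens) for cytotoxicity, read by MTT assay, with a stated time of 24 h (a lower number here means a stronger inhibitor, a higher number a weaker inhibitor), compound 1 reaches only a limit, > 100000 nM. Compound 2 likewise reaches only a limit in this assay, > 100000 nM. The two differ by fluoro in place of methyl on an aromatic carbon, and the resulting step that the two limits leave unreadable from compound 2 to compound 1 cannot be read, because of the limit of > 100000 nM in this assay, at which 2 of the 3 values shown sit. Among the compounds with values here, compound 3 is the one compound with a number, 12800 nM; how its core differs from that of compound 2 is not broken down here.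

Compound 4 `C#CCn1c(=O)c(/C=C/C(=O)/C=C(O)/C=C/c2ccc(O)c(OC)c2)cc2cc(F)ccc21` is not yet measured. It differs from compound 3 by fluoro in place of methyl on an aromatic carbon, the same change as that between compound 2 and compound 1. As that earlier step is unreadable, the expectation rests on compound 3 alone: because compound 3 gives 12800 nM, compound 4 is expected to sit near it, with an expected step of a 1.0-fold higher number from compound 3 to compound 4 (0.01 log units; within the scatter). Compound 4 is therefore estimated at 13000 nM, likely between 4000 nM and 40000 nM.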

Compound 4, half-maximal inhibitory concentration: > 100000 nM
Compound 4: only a limit was reported; the forecaster's own chance of this, stated with the estimate: 10%; at least 7.6-fold (0.88 log units) between middle value and limit.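

In this assay, on these data alone, fluoro in place of methyl on an aromatic carbon gives an at least 7.8-fold higher number from compound 3 to compound 4 (0.89 log units; beyond the scatter), so on the core of compound 3 this one swap costs activity, by an amount whose full size stays unknown. Compound 4 gives > 100000 nM, which is a limit of the assay and not a number. This does not show that the change carries over from one core to another, as the step from compound 2 to compound 1 cannot be read, leaving a single readable pair, and this is because both compounds sit at that limit: the limit of > 100000 nM in this assay, at which 3 of the 4 values shown sit.

The compounds shown leave open whether another group on the same aromatic carbon, such as chloro or an amine, would keep or improve on the value of compound 3, which gives 12800 nM. Also open, as far as these compounds go, is whether the swap would cost as much on a core with a shorter chain than that of compound 3, if such a core gave a measurable number.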